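This account rests on a few compounds, and the source may have more. Where it says the series, first, only, none or still open, it means among the compounds named here.

Measured so far:
- compound 1, `O=C1NNC(=O)C2(CSC3=C2C(=O)c2ncccc2C3=O)N1`: 980 nM
- compound 2, `O=C1C2=C(C(=O)c3ncccc31)C1(CS2)NC(=O)N(c2ccccc2)C1=O`: 3 nM

Of the compounds shown here, two have been tested in a functional assay on HeLa cells (Homo sapiens) for antiproliferative activity, read by MTT assay, with a stated time of 96 h; on this read-out higher numbers stand for weaker inhibition and lower numbers for stronger inhibition. Compound 1, `O=C1NNC(=O)C2(CSC3=C2C(=O)c2ncccc2C3=O)N1`, gives 980 nM. Compound 2, `O=C1C2=C(C(=O)c3ncccc31)C1(CS2)NC(=O)N(c2ccccc2)C1=O`, gives 3 nM. Among the measured compounds shown here, of the two numbers, the one for compound 2 is the lower, and the gap between the two values lies far beyond the scatter of the method, so compound 2 stands as the stronger inhibitor of the pair.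

Compound 3, `CN(C)c1ccc(N2C(=O)NC3(CSC4=C3C(=O)c3ncccc3C4=O)C2=O)cc1`, has not yet been measured. It differs from compound 2 in one place: dimethylamino in place of hydrogen on an aromatic carbon. The change sits on an aromatic carbon of a six-membered aromatic ring of carbon only, on the phenyl attached to the core of compound 2.

For the measured compounds named here, with no measured pair showing what such a change does, the account rests on compound 2 alone. The step from compound 2 to compound 3 is expected to be small, in neither direction beyond the scatter, as a 1.7-fold higher number from compound 2 to compound 3 (0.22 log units; within the scatter). Compound 3 is estimated at 5 nM, within a range of 1.5 nM to 25 nM.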

Compound 3, half-maximal inhibitory concentration: 10 nM
Beside the measured number, compound 3's estimate is 2.0-fold (0.30 log units) below it; the range from low to high includes it.
By their numbers in this assay, from the lowest: compound 2; then compound 3; then compound 1.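

The phenyl attached to the core of compound 2 is now shown to respond to substitution: in this assay, replacing hydrogen with dimethylamino on an aromatic carbon, para to a large group, gives a 3.3-fold higher number from compound 2 to compound 3 (0.52 log units; beyond the scatter). The step is modest, yet it lies beyond the scatter, so this carbon is not a silent position, and the change from phenyl to 4-(dimethylamino)phenyl carries a measurable cost. That cost is limited, since compound 3 still gives 10 nM, and nothing available here accounts for the step or ties it to any property of the group.

As far as these compounds go, a single step cannot show whether the rise in the number belongs to dimethylamino in particular or would follow any group placed on this carbon, so it remains open how a primary amine, a methoxy group, a fluorine atom or a carboxylic acid would behave there. The compounds shown also leave open how dimethylamino would fare on the other carbons of this ring, and whether a longer chain on the nitrogen would widen or narrow the step.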